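Removing the Bromine: A Step Expected to Change Little

A few compounds are considered here, and "the series" means these few. Any claim that something is new, unique, unknown or untested is made for them only; others in the source may bear on it.

Measured in a functional assay on B16-F10 cells (Mus musculus) for cytotoxicity; on this read-out higher numbers stand for weaker inhibition and lower numbers for stronger inhibition:
Compound 1 `O=c1oc2ccccc2c2nc3c(ccc4cc[nH]c43)c(-c3cccc(Br)c3)c12` gives 70700 nM.
Compound 2 `O=c1oc2ccccc2c2nc3c(ccc4cc[nH]c43)c(-c3c(Cl)cccc3Cl)c12` gives 70700 nM.
Compound 3 `O=c1oc2ccccc2c2nc3c(ccc4cc[nH]c43)c(-c3ccccc3Br)c12` gives 70700 nM.

Compound 1 stands level with compounds 2 and 3 at the digits shown; the steps of no change at the digits printed from compound 1 to compound 2 (within the scatter), no change at the digits printed from compound 1 to compound 3 (within the scatter) and no change at the digits printed from compound 2 to compound 3 (within the scatter) all stay within the scatter. Compound 4 `O=c1oc2ccccc2c2nc3c(ccc4cc[nH]c43)c(-c3ccccc3)c12` differs from compound 1 by hydrogen in place of bromo on an aromatic carbon. For the measured compounds named here, none of the measured steps removes a halogen outright; they only move or exchange halogens on the same phenyl, and each left the reading in this assay unchanged. On that basis no step beyond the scatter is expected: no change at the digits printed from compound 1 to compound 4 (within the scatter). Compound 4 is therefore estimated at 70700 nM, with a range from 35000 nM to 141000 nM.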

Compound 4, half-maximal inhibitory concentration: 70700 nM
Estimate against measurement, compound 4: no gap at the digits printed; low and high end bracket the measured number.
By their numbers in this assay, from the lowest: compounds 1, 2, 3 and 4 (each within the scatter of the next).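

For the compounds shown here, compound 4 is the first compound here with no halogen at all on this phenyl, and in this assay losing the bromo gives no change at the digits printed from compound 1 to compound 4 (within the scatter) and likewise no change at the digits printed from compound 3 to compound 4 (within the scatter) as the measured result. Replacing 2,6-dichlorophenyl with phenyl gives no change at the digits printed from compound 2 to compound 4 (within the scatter) as well. Among these four compounds, then, a bromo or chloro on this phenyl is not needed for this reading. Still open, from the compounds shown here alone, is whether an amine or a carboxylic acid on this phenyl would shift the reading. No supporting measurement explains the unchanged reading.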